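The source may report more compounds than this note shows. Statements on the series, on what has been measured and on what is new or still open speak of the compounds shown alone.

Measured so far:
compound 1 `O=C(NO)c1ccc(N(Cc2ccc(C3CCCCC3)cc2)C(=O)[C@H]2CCN2S(=O)(=O)c2c(F)c(F)c(F)c(F)c2F)cc1O`: 5100 nM
compound 2 `O=C(NO)c1ccc(N(Cc2cnc(C3CCCCC3)cn2)C(=O)[C@H]2CCN2S(=O)(=O)c2c(F)c(F)c(F)c(F)c2F)cc1O`: 5200 nM

Both numbers come from a functional assay on MDA-MB-231 cells (Homo sapiens) for antiproliferative activity, with a stated time of 72 h; a lower number here means that less compound is needed, a higher number that more compound is needed for the effect. Within the data shown here, compound 2 stands highest of the two numbers, but its only neighbour, compound 1, is separated from it by a 1.0-fold higher number from compound 1 to compound 2 (0.01 log units; within the scatter), so the two cannot be told apart. Compound 3 `O=C([C@H]1CCN1S(=O)(=O)c1c(F)c(F)c(F)c(F)c1F)N(Cc1cnc(C2CCCCC2)cn1)c1ccc2nn[nH]c2c1` has not yet been measured. It differs from compound 2 in one place: a group of 9 heavy atoms (6 carbon, 3 nitrogen; one five-membered aromatic ring with 3 hetero atoms, one six-membered aromatic ring of carbon only) in place of a group of 11 heavy atoms (7 carbon, 1 nitrogen, 3 oxygen; one six-membered aromatic ring of carbon only), on an amide-type nitrogen. Among the measured compounds shown here, the single measured step concerns a different place in the molecule, the saturated chain carbon bound to the amide-type nitrogen, and therefore gives no guide to the present change. For the measured compounds named here, with no comparable step in hand, the expectation can only be cautious and broad. Compound 3 is estimated to give 20000 nM in this assay, with a range from 4000 nM to 100000 nM. That estimate corresponds to an expected step of a 3.8-fold higher number from compound 2 to compound 3 (0.59 log units; beyond the scatter), held with low confidence.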

Compound 3, half-maximal effective concentration: 2100 nM
Beside the measured number, compound 3's estimate is 9.5-fold (0.98 log units) above it, outside the stated range (below it).
By their numbers in this assay, from the lowest: compound 3; then compounds 1 and 2 (each within the scatter of the next).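

Among these compounds, the one earlier step changed the group on the saturated chain carbon, whereas this pair gives the first reading on the group attached directly to the amide-type nitrogen. In this assay, replacing 3-hydroxy-4-(hydroxycarbamoyl)phenyl with a group made of a five-membered aromatic ring with 3 hetero atoms and a six-membered aromatic ring of carbon only gives a 2.5-fold lower number from compound 2 to compound 3 (0.39 log units; beyond the scatter), so in this pair the activity does not depend on the departing group. No measurement shown here explains why the number falls.

A plain phenyl or a phenyl carrying a carboxylic acid at this position would help show which part of each group matters. From the compounds shown here alone, all of this rests on one pair with 5-cyclohexylpyrazin-2-yl, so whether the step holds with 4-cyclohexylphenyl remains open.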